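A few compounds are considered here, and "the series" means these few. Any claim that something is new, unique, unknown or untested is made for them only; others in the source may bear on it.

Of the compounds shown here, three sharing one core have been tested in a functional assay on NCI-H460 cells (Homo sapiens) for cytotoxicity, read by MTT assay (a higher number here means a weaker inhibitor, a lower number a stronger inhibitor), and a fourth is to follow. Compound 3 `Cc1cccc(Nc2nc(C)c(C(=O)/C=C/c3ccccc3)s2)c1` carries a 3-methylphenyl on the ring nitrogen and an unsubstituted phenyl on the enone, and in this assay compound 3 gives 21800 nM. Compound 1 `COc1cccc(/C=C/C(=O)c2sc(Nc3cccc(C)c3)nc2C)c1` differs from it by methoxy in place of hydrogen on an aromatic carbon. In this assay compound 1 reaches only a limit, > 25000 nM. That step, an at least 1.1-fold higher number from compound 3 to compound 1 (0.05 log units; that floor lies within the scatter), is therefore known only as a floor. Compound 2 `Cc1ccccc1Nc1nc(C)c(C(=O)/C=C/c2ccccc2)s1` differs from compound 3 in the two cores, by 2-methylphenyl in place of 3-methylphenyl on a nitrogen on an aromatic ring. In this assay compound 2 likewise reaches only a limit, > 25000 nM. The step of an at least 1.1-fold lower number from compound 2 to compound 3 (0.05 log units; that floor lies within the scatter) is again only a floor, resting on (the limit of > 25000 nM in this assay, at which 2 of the 3 values shown sit).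

Compound 4 `COc1cccc(/C=C/C(=O)c2sc(Nc3ccccc3C)nc2C)c1` is not yet measured; it differs from compound 2 by methoxy in place of hydrogen on an aromatic carbon. The place of this change reads the same word for word as in the step from compound 3 to compound 1, so it is the same change made on the core of compound 2. Since compound 2 already sits at the limit and the earlier step of an at least 1.1-fold higher number from compound 3 to compound 1 (0.05 log units; that floor lies within the scatter) gave no gain, the expected step that the limit leaves unreadable from compound 2 to compound 4 is also no gain, most likely ending at the limit again. Compound 4 is expected to give about 32000 nM, somewhere from 18000 nM to 70000 nM.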

Compound 4, half-maximal inhibitory concentration: > 25000 nM
Compound 4 gave a limit, no number; the forecaster's own chance of this, stated with the estimate: 80%; the middle value lies beyond the limit too.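

In this assay compound 4 reaches only a limit, > 25000 nM. No step from compound 2 or compound 1 to compound 4 can be read, because each pair has a limit at both ends: the limit of > 25000 nM in this assay, at which 3 of the 4 values shown sit.

The compounds shown leave open how much methoxy in place of hydrogen changes the number on the core of compound 2, and how much 2-methylphenyl in place of 3-methylphenyl changes it on the core of compound 1.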